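This account rests on a few compounds, and the source may have more. Where it says the series, first, only, none or still open, it means among the compounds named here.

Compound 1 `COc1ccc(C(=O)N2CCN(Cc3nc4ccccc4n3Cc3cccc(C)c3)CC2)cc1` gives 55.5% in an assay on isolated protein for inhibition of aldehyde dehydrogenase 1A1 (Homo sapiens), read by spectrophotometry, tested at 10 uM; a lower number here means less inhibition, a higher number more inhibition at the concentration tested (going by the name of the read-out).
Compound 2 `CC(C)Cn1c(CN2CCN(C(=O)C3CC3)CC2)nc2ccccc21` gives 13.1% in this assay.

Within the data shown here, on these two numbers compound 1 stands highest; its only neighbour, compound 2, lies lower by a margin beyond the scatter. Compound 3 `Cc1cccc(Cn2c(CN3CCN(C(=O)c4ccc(Br)cc4)CC3)nc3ccccc32)c1` has not yet been measured in this assay. It differs from compound 1 in one place: bromo in place of methoxy on an aromatic carbon. Among the measured compounds shown here, no step between measured compounds covers this change, so its size is unknown. The step from compound 1 to compound 3 is expected to be small, a number 5.5 percentage points lower from compound 1 to compound 3 (within the scatter), possibly none beyond the scatter. Compound 3 is therefore estimated at 50%, in a range from 25% to 75%.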

Compound 3, a percentage reported as inhibition, at one concentration (the size of the read-out at that concentration, not a potency): 25.8%
Compound 3: the middle estimate sits 24.2 percentage points above what was measured, and the stated range covers the measured number.
By their numbers in this assay, from the lowest: compound 2; then compound 3; then compound 1.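

In this assay, the aromatic carbon para to a large group proves sensitive to what it carries: bromo in place of methoxy gives a number 29.7 percentage points lower from compound 1 to compound 3 (beyond the scatter) on an otherwise unchanged structure. Among these compounds, this is the first single-place change, so it shows that the 4-methoxyphenyl group cannot be exchanged freely for 4-bromophenyl. No measurement at hand explains this step. As far as these compounds go, whether fluoro or an amine at this position would stand nearer compound 1 or compound 3 stays open. So does whether the same change would give a similar step with a different group on the shared core.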